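Chain-length step in a triazole-linked aminosugar series

The compounds below may be only part of what the source reports. "The series", "measured", "known", "first", "only" and "open" are said of these compounds alone.

Measured so far:
Compound 1, `CCCCCCCCCn1cc(COC[C@@H]2OC[C@H](N)[C@@H]2O)nn1`, gives 20100 nM in a functional assay on EC9706 cells (Homo sapiens) for antiproliferative activity, read by MTT assay, with a stated time of 48 h; on this read-out higher numbers stand for weaker inhibition and lower numbers for stronger inhibition.
Compound 2, `CCCCCCCCCCn1cc(COC[C@@H]2OC[C@H](N)[C@@H]2O)nn1`, gives 15600 nM in this assay.
Compound 3, `CCCCCCCn1cc(COC[C@@H]2OC[C@H](N)[C@H]2O)nn1`, gives only a limit in this assay, > 128000 nM.

The step of a 1.3-fold lower number from compound 1 to compound 2 (0.11 log units; within the scatter) follows from methyl in place of hydrogen on a saturated chain carbon, nine bonds along the chain from an aromatic nitrogen. Compound 3 carries a core whose difference from the core of compound 1 is not broken down here; its value is a limit of this assay, (the limit of > 128000 nM in this assay, at which 1 of the 3 values shown sits). Compound 4, `CCCCCCCCn1cc(COC[C@@H]2OC[C@H](N)[C@H]2O)nn1`, is not yet measured; it differs from compound 3 by methyl in place of hydrogen on a saturated chain carbon, seven bonds along the chain from an aromatic nitrogen, the same kind of change as between compound 1 and compound 2, but sitting seven rather than nine bonds along the chain from an aromatic nitrogen. The expected step is an at least 1.1-fold lower number from compound 3 to compound 4 (0.06 log units; that floor lies within the scatter), resting on the flat step a 1.3-fold lower number from compound 1 to compound 2 (0.11 log units; within the scatter). For compound 4 the estimate in this assay is 110000 nM, spanning 30000 nM to 400000 nM, with a real chance that only a limit is returned.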

Compound 4, half-maximal inhibitory concentration: > 128000 nM
Compound 4 gave a limit, no number; the forecaster's own chance of this, stated with the estimate: 50%; at least 1.1-fold (0.06 log units) between middle value and limit.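

Compound 3 and compound 4 each return only a limit in this assay, so no step can be read between them: the limit of > 128000 nM in this assay, at which 2 of the 4 values shown sit.

The compounds shown leave open whether lengthening the chain changes activity at all on the core shared by compound 3 and compound 4.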